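This account rests on a few compounds, and the source may have more. Where it says the series, first, only, none or still open, it means among the compounds named here.

Measured in an ADME assay on MT4 cells (Homo sapiens) for activation, read by MTT assay; a lower number here means that less compound is tolerated, a higher number that more compound is tolerated:
Compound 1 `CCCCSc1nc(Cc2c(F)cccc2Cl)c(C)c(=O)[nH]1`: > 73000 nM (a limit)
Compound 2 `CCCSc1nc(C(C)c2c(F)cccc2Cl)c(C)c(=O)[nH]1`: > 1500 nM (a limit)
Compound 3 `CCCCSc1nc(C(C)c2c(F)cccc2Cl)c(C)c(=O)[nH]1`: > 1500 nM (a limit)

For the measured compounds named here, no compound in this set has a measured number. Compound 3 sits at the limit of > 1500 nM in this assay, at which 2 of the 3 values shown sit. Compound 1 alone sits at the limit of > 73000 nM in this assay, at which 1 of the 3 values shown sits.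

Compound 4 `CCCCSc1nc(C(C)c2c(F)cccc2Cl)c(CC)c(=O)[nH]1` differs from compound 3 by one change, methyl to ethyl: methyl in place of hydrogen on a saturated chain carbon bound to an aromatic carbon.

The two measured steps into compound 3 are also methyl in place of hydrogen on a saturated chain carbon. Going by the values given here, the first is a step that the two limits leave unreadable from compound 1 to compound 3. The second is a step that the two limits leave unreadable from compound 2 to compound 3. Neither has a size that can be read, so they set no size and no direction for the new step, and no shift beyond the scatter is expected in this assay. The likeliest report for compound 4 is again a limit.

The expected change is a step that the limit leaves unreadable from compound 3 to compound 4. If a number is obtained, compound 4 is expected at 10000 nM, with an estimated range from 1500 nM to 100000 nM.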

Compound 4, half-maximal cytotoxic concentration: > 3000 nM
Compound 4: a limit, no number; the forecaster's own chance of this, stated with the estimate: 75%; the middle value lies beyond the limit too.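

In this assay compound 4 gives > 3000 nM, a limit. Compound 3 gives > 1500 nM, also a limit. The step between these two compounds therefore cannot be read. The compounds shown leave open where any actual half-maximal cytotoxic concentration lies, and whether methyl to ethyl shifts it.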